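Cytotoxicity of the shared core with ring substituents

A few compounds are considered here, and "the series" means these few. Any claim that something is new, unique, unknown or untested is made for them only; others in the source may bear on it.

Compound 1 `COc1cc(CC(O)c2ccc(-c3ccc(CO)cc3)cc2)c([N+](=O)[O-])cc1OC` carries a 4-(hydroxymethyl)phenyl group on an aromatic carbon of the shared core. For the measured compounds named here, in an ADME assay on HeLa Rh cells (Homo sapiens) for cytotoxicity, read by microscopy (on this read-out lower numbers stand for higher toxicity in this test and higher numbers for lower toxicity in this test), compound 1 gives only a limit, > 244000 nM, and no number; it is the one value of the series that sits at that limit, (the limit of > 244000 nM in this assay, at which 1 of the 3 values shown sits). Compound 2 `COc1cc(CC(O)c2ccc(-c3cccc(F)c3)cc2)c([N+](=O)[O-])cc1OC` gives 7400 nM in this assay, and compound 3 `COc1cc(CC(O)c2ccc(-c3cccc([N+](=O)[O-])c3)cc2)c([N+](=O)[O-])cc1OC` gives 5500 nM. The step of an at least 32-fold lower number from compound 1 to compound 2 (1.51 log units; beyond the scatter) and the step of an at least 44-fold lower number from compound 1 to compound 3 (1.64 log units; beyond the scatter) are both large, and between the two substituted analogues the step of a 1.3-fold lower number from compound 2 to compound 3 (0.13 log units; within the scatter) is within the scatter.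

Compound 4 `COc1cc(CC(O)c2ccc(-c3ccccc3[N+](=O)[O-])cc2)c([N+](=O)[O-])cc1OC` is not yet measured. Its change from compound 1 is 2-nitrophenyl in place of 4-(hydroxymethyl)phenyl on an aromatic carbon. The two measured steps that bear on it both replace the 4-(hydroxymethyl)phenyl group by a substituted phenyl and both lower the number strongly, so a large step down in the same direction is expected here too. The step from compound 1 to compound 4 is estimated as an at least 34-fold lower number from compound 1 to compound 4 (1.54 log units; beyond the scatter). For compound 4 a value of 7000 nM is expected, within the range 2500 nM to 25000 nM.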

Compound 4, half-maximal cytotoxic concentration: 9500 nM
Compound 4: middle estimate off by 1.4-fold (0.13 log units), on the low side, and the stated range covers the measured number.
By their numbers in this assay, from the lowest: compounds 3, 2 and 4 (each within the scatter of the next). At a limit, above all of these: compound 1.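

In this assay, 2-nitrophenyl in place of 4-(hydroxymethyl)phenyl gives an at least 25-fold lower number from compound 1 to compound 4 (1.40 log units; beyond the scatter), so the large step now holds for three different substituted phenyl groups at this place. Moving the nitro group on the ring changes nothing that can be read, with a 1.7-fold higher number from compound 3 to compound 4 (0.24 log units; within the scatter), and exchanging the fluoro-bearing ring for the nitro-bearing one gives a 1.3-fold higher number from compound 2 to compound 4 (0.11 log units; within the scatter). The sizes of the steps away from compound 1 remain bounds only, because compound 1 gives a limit and no number: the limit of > 244000 nM in this assay, at which 1 of the 4 values shown sits.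

Open, going by these compounds, is whether the limit of compound 1 follows the hydroxymethyl group itself or its place on the ring. Also open, on these data alone, is whether a primary amine or a carboxylic acid on that ring would read like compound 1 or like compound 4.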